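This account rests on a few compounds, and the source may have more. Where it says the series, first, only, none or still open, it means among the compounds named here.

Compound 1, `c1ccc2c(c1)CC2CCCCN1CCN(c2cccc3c2OCCO3)CC1`: > 10 mg/kg
Compound 2, `C1=C(CCN2CCN(c3cccc4c3OCCO4)CC2)c2ccccc2C1`: > 2.5 mg/kg
Compound 3, `C1=C(CCN2CCN(c3cccc4c3OCCO4)CC2)c2ccccc2CCC1`: > 40 mg/kg

In a functional assay on the whole organism for agonist activity, with Rattus norvegicus as the target (a lower number here means that less compound is needed, a higher number that more compound is needed for the effect), compound 1 gives > 10 mg/kg, which is a limit of the measurement and not a number. Compound 2 also sits at a limit, > 2.5 mg/kg. Compound 3 likewise reaches only a limit, > 40 mg/kg. Going by the values given here, compound 1 therefore stands on no number at all; the three results are all limits (the limit of > 10 mg/kg in this assay, at which 1 of the 3 values shown sits, (the limit of > 2.5 mg/kg in this assay, at which 1 of the 3 values shown sits), (the limit of > 40 mg/kg in this assay, at which 1 of the 3 values shown sits)), and no two of the measured compounds differ in one place, so no step between them is known.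

Compound 4, `c1ccc2c(c1)CC(CCCN1CCN(c3cccc4c3OCCO4)CC1)C2`, differs from compound 1 in a single change: a group of 9 heavy atoms (9 carbon; one five-membered non-aromatic ring of carbon only, one six-membered aromatic ring of carbon only) in place of a group of 9 heavy atoms (9 carbon; one four-membered non-aromatic ring of carbon only, one six-membered aromatic ring of carbon only), on a saturated chain carbon, three bonds along the chain from an amine nitrogen in a ring. Among the compounds with values here, with no measured step to lean on, the expected step that the limit leaves unreadable from compound 1 to compound 4 in this assay is no larger than the scatter, in no preferred direction. Compound 4 is expected to give about 20 mg/kg in this assay, within 5 mg/kg to 80 mg/kg, and most probably again only a limit rather than a number.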

Compound 4, minimum effective dose: 40 mg/kg
Compound 4: the middle estimate sits 2.0-fold (0.30 log units) below what was measured, and the stated range covers the measured number.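

In this assay no step from compound 1 to compound 4 can be read, as compound 1 gives only a limit and not a number: the limit of > 10 mg/kg in this assay, at which 1 of the 4 values shown sits.

The compounds shown leave open whether the 2,3-dihydro-1H-inden-2-yl group of compound 4 needs more or less compound for the effect than the group it replaces in compound 1.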